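A few compounds are considered here, and "the series" means these few. Any claim that something is new, unique, unknown or untested is made for them only; others in the source may bear on it.

Working notes on the series.

Compound 1 `Cc1ccccc1Nc1ncnn1-c1cccc(Cl)c1Cl` and compound 2 `CCc1ccccc1Nc1ncnn1-c1cccc(Cl)c1Cl` share one core and differ only in the group on the benzene ring. In a functional assay for antagonist activity at P2X purinoceptor 7 (Rattus norvegicus), read by FLIPR and calcium flux (a higher number here means a weaker inhibitor, a lower number a stronger inhibitor), compound 1 gives 240 nM, and in this assay compound 2 gives 288 nM. Among the measured compounds shown here, the only measured step is a 1.2-fold higher number from compound 1 to compound 2 (0.08 log units; within the scatter). Compound 2 therefore gives the higher of the two numbers, but within the scatter of compound 1, so no order between them is claimed.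

Compound 3 `FC(F)(F)Oc1ccccc1Nc1ncnn1-c1cccc(Cl)c1Cl` is next and has not been measured in this assay. The change from compound 2 is trifluoromethoxy in place of ethyl on an aromatic carbon. For the measured compounds named here, no measured step involves this group, and the one step at hand bears on the change only in that it sits at the same place on the ring. The step from compound 2 is therefore expected to be a 1.2-fold higher number from compound 2 to compound 3 (0.08 log units; within the scatter), with wide uncertainty. Compound 3 is estimated at 350 nM in this assay, between 100 nM and 1200 nM.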

Compound 3, half-maximal inhibitory concentration: 5500 nM
For compound 3 the middle estimate is 16-fold (1.20 log units) below the measured one; the whole stated range lies below it.
By their numbers in this assay, from the lowest: compounds 1 and 2 (each within the scatter of the next); then compound 3.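

Methyl and ethyl at this position read within the scatter of each other, but trifluoromethoxy in this assay gives a 19-fold higher number from compound 2 to compound 3 (1.28 log units; beyond the scatter) and a 23-fold higher number from compound 1 to compound 3 (1.36 log units; beyond the scatter) on the same core, so the position does respond to the group it carries. Compared with ethyl, trifluoromethoxy differs at once in heavy atoms, in oxygen and fluorine, and in having a hydrogen-bond acceptor, and this single step cannot separate these differences. Nothing measured on these compounds accounts for the weaker inhibition of compound 3.

Still open, going by these compounds, is how methoxy, trifluoromethyl or a longer chain such as propyl would read at this position, and so whether the oxygen, the fluorine or the size of the group follows the higher number. Also open, on these data alone, is whether hydrogen or chlorine here would give a lower number than compound 1 and compound 2 do.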